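Compound 3: a thiophene for a methylphenyl ring

This account rests on a few compounds, and the source may have more. Where it says the series, first, only, none or still open, it means among the compounds named here.

Measured so far in an ADME assay on L6 cells (Rattus norvegicus) for cytotoxicity, read by resazurin assay, with a stated time of 72 h; a higher number here means a weaker inhibitor, a lower number a stronger inhibitor:
Compound 1 `OC(c1ccc(Cl)cc1)(c1cccnc1)c1ccccc1Cl` gives 61300 nM
Compound 2 `Cc1ccccc1C(O)(c1ccc(Cl)cc1)c1cccnc1` gives 82000 nM

In this assay compound 2 stands at 82000 nM and lies within the scatter of compound 1 at 61300 nM on this pair of numbers. Among the compounds with values here, the only measured step, methyl in place of chloro on an aromatic carbon, is a 1.3-fold higher number from compound 1 to compound 2 (0.13 log units; within the scatter) and bears only loosely on what follows. Compound 3 `OC(c1ccc(Cl)cc1)(c1cccnc1)c1cccs1` has thiophen-2-yl in place of 2-methylphenyl on a saturated chain carbon bound to two aromatic carbons and an oxygen on a saturated carbon, counted as thiophen-2-yl in place of 2-methylphenyl on a saturated chain carbon bound to two aromatic carbons and an oxygen on a saturated carbon here. Within the data shown here, no measured step exchanges a whole ring, so no shift beyond the scatter is expected in either direction. The expected change is a 1.2-fold lower number from compound 2 to compound 3 (0.07 log units; within the scatter) and nothing larger is foreseen. For compound 3 the estimated value is 70000 nM with an expected range from 30000 nM to 150000 nM in this assay.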

Compound 3, half-maximal inhibitory concentration: 67700 nM
For compound 3 the middle estimate is 1.0-fold (0.01 log units) above the measured one; the measured number falls inside the stated range.
By their numbers in this assay, from the lowest: compounds 1, 3 and 2 (each within the scatter of the next).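

Exchanging a whole ring at this place, on a saturated chain carbon bound to two aromatic carbons and an oxygen on a saturated carbon, gives a 1.2-fold lower number from compound 2 to compound 3 (0.08 log units; within the scatter) in this assay, and thiophen-2-yl in place of 2-chlorophenyl gives a 1.1-fold higher number from compound 1 to compound 3 (0.04 log units; within the scatter). The earlier pair differed only by methyl in place of chloro on an aromatic carbon, whereas this place has now held a five-membered aromatic ring with a sulfur atom as well as two six-membered aromatic rings of carbon only, with no step beyond the scatter. Nothing on hand offers a reason for these small steps.

The compounds shown leave open whether a group without a ring, such as a longer chain, or a ring carrying an amine or a carboxylic acid, would move the number beyond the scatter. They also leave open whether changes elsewhere on the shared core would do so.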